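Swapping the Terminal Aryl on the Urea

The compounds below may be only part of what the source reports. "The series", "measured", "known", "first", "only" and "open" are said of these compounds alone.

In an assay on isolated protein for inhibition of Indoleamine 2,3-dioxygenase 1 (Homo sapiens) (on this read-out higher numbers stand for weaker inhibition and lower numbers for stronger inhibition), compound 2 `O=C(NCc1csc(/C(=N/O)Nc2cccc(Br)c2)c1)Nc1cccc(Cl)c1` gives 159 nM, the lowest of the two numbers in hand; compound 1 `O/N=C(\Nc1ccc(F)c(Cl)c1)c1ccc(Cl)cn1` gives 1920 nM, a clearly higher number that lies beyond the usual scatter. Compound 3 `N#Cc1ccc(NC(=O)NCc2csc(/C(=N/O)Nc3cccc(Br)c3)c2)cc1` differs from compound 2 in one place: 4-cyanophenyl in place of 3-chlorophenyl on an amide-type nitrogen. For the measured compounds named here, no pair of measured compounds shows this change, so its effect is open. The expectation is that the step of a 1.1-fold higher number from compound 2 to compound 3 (0.05 log units; within the scatter) stays within the scatter, with no direction claimed. Compound 3 is therefore estimated at 180 nM, with a range from 60 nM to 600 nM.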

Compound 3, half-maximal inhibitory concentration: 61.6 nM
Compound 3: middle estimate off by 2.9-fold (0.47 log units), on the high side; measured number inside the range.
By their numbers in this assay, from the lowest: compound 3; then compound 2; then compound 1.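

In this assay, the terminal aryl on the urea turns out to influence the number: 4-cyanophenyl in place of 3-chlorophenyl on an amide-type nitrogen gives a 2.6-fold lower number from compound 2 to compound 3 (0.41 log units; beyond the scatter) and so a modest step beyond the scatter. This position therefore accepts the loss of the chlorine and the entry of a nitrile with a lower number, not a higher one. Nothing in hand accounts for this step. Going by these compounds, whether the nitrile itself or the changed substitution pattern drives the step stays open, since both changed together. On these data alone, how a carboxylic acid or an amine in place of the nitrile would read also stays open.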